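A methyl added to the butyl chain of compound 3

The compounds below may be only part of what the source reports. "The series", "measured", "known", "first", "only" and "open" are said of these compounds alone.

In a functional assay on A549 cells (Homo sapiens) for antiproliferative activity, read by MTT assay, with a stated time of 48 h (on this read-out lower numbers stand for stronger inhibition and higher numbers for weaker inhibition), compound 3 (`CCCCC1(O)C(=O)Nc2ccc(Nc3ccc(C)cc3)cc21`) gives 7500 nM as the only number shown. Compound 1 (`Cc1ccc(Nc2ccc3c(c2)C(CC2CCCCC2)C(=O)N3)cc1`) gives > 30000 nM as a limit and not a number. Compound 2 (`COc1ccc(Nc2ccc3c(c2)C(O)(Cc2ccccc2)C(=O)N3)cc1`) likewise gives > 30000 nM as a limit.

Compound 4 (`Cc1ccc(Nc2ccc3c(c2)C(O)(CCC(C)C)C(=O)N3)cc1`) departs from compound 3 by a single edit (methyl in place of hydrogen on a saturated chain carbon bound to two saturated chain carbons): methyl in place of hydrogen on a saturated chain carbon bound to two saturated chain carbons, which turns butyl into isopentyl. For the measured compounds named here, no measured pair tests this edit, so in this assay no step beyond the scatter is expected, in either direction. The expected step of a 1.1-fold higher number from compound 3 to compound 4 (0.03 log units; within the scatter) is therefore small. For compound 4 the estimate is 8000 nM with an expected range of 3000 nM to 25000 nM on this read-out.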

Compound 4, half-maximal inhibitory concentration: 12500 nM
For compound 4 the middle estimate is 1.6-fold (0.19 log units) below the measured one; the range from low to high includes it.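

In this assay, for the compounds shown here, the only measured pair for this change shows a 1.7-fold higher number from compound 3 to compound 4 (0.22 log units; within the scatter). Methyl in place of hydrogen at this saturated chain carbon, which turns butyl into isopentyl, thus leaves the read-out within the usual scatter, and the position accepts the extra methyl with no measurable change. Both compounds give real numbers, which is not true of the whole set: the limit of > 30000 nM in this assay, at which 2 of the 4 values shown sit.

Going by these compounds, it remains open whether a longer chain, an amine or a carboxylic acid in place of the isopentyl group would also leave the read-out unchanged.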